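Removing the fluoro from the aryl group of compound 3

The compounds below may be only part of what the source reports. "The series", "measured", "known", "first", "only" and "open" are said of these compounds alone.

Three compounds of a shared core have been run in a functional assay on HeLa cells (Homo sapiens) for cytotoxicity, read by WST assay, with a stated time of 48 h; a lower number here means a stronger inhibitor, a higher number a weaker inhibitor. Compound 1 `O[C@@H](c1ccccc1)[C@H]1CO[C@H](c2ccccc2)[C@@H](C/C=C/c2ccncc2)C1` carries a pyridin-4-yl on the double-bonded chain carbon, and in this assay compound 1 reaches only the limit > 100000 nM (the limit of > 100000 nM in this assay, at which 1 of the 3 values shown sits). Compound 2 `COc1ccccc1/C=C/C[C@H]1C[C@@H]([C@@H](O)c2ccccc2)CO[C@@H]1c1ccccc1` bears a 2-methoxyphenyl in that place, and in this assay compound 2 gives 14700 nM. Compound 3 `O[C@@H](c1ccccc1)[C@H]1CO[C@H](c2ccccc2)[C@@H](C/C=C/c2cccc(F)c2)C1` bears a 3-fluorophenyl, and in this assay compound 3 gives 8380 nM. The steps of an at least 6.8-fold lower number from compound 1 to compound 2 (0.83 log units; beyond the scatter) and an at least 11-fold lower number from compound 1 to compound 3 (1.07 log units; beyond the scatter) are beyond the scatter, whereas a 1.8-fold lower number from compound 2 to compound 3 (0.24 log units; within the scatter) is not, so compound 3 and compound 2 stand side by side, with compound 1 set apart from both.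

Compound 4 `O[C@@H](c1ccccc1)[C@H]1CO[C@H](c2ccccc2)[C@@H](C/C=C/c2ccccc2)C1` is compound 3 with hydrogen in place of fluoro on an aromatic carbon. For the measured compounds named here, the exchange of one substituted phenyl for another between compound 2 and compound 3 gave no step beyond the scatter; the only steps beyond it replaced pyridin-4-yl by a phenyl ring. Losing a single fluoro is a smaller change than either, so compound 4 is expected to move little in this assay, a 1.2-fold higher number from compound 3 to compound 4 (0.08 log units; within the scatter). Compound 4 is therefore estimated at 10000 nM, within 4000 nM to 30000 nM.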

Compound 4, half-maximal inhibitory concentration: 6060 nM
Compound 4: the middle estimate sits 1.7-fold (0.22 log units) above what was measured, within the range that was stated.
By their numbers in this assay, from the lowest: compounds 4, 3 and 2 (each within the scatter of the next, the first and the last beyond it). At a limit, above all of these: compound 1.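

In this assay, a 1.4-fold lower number from compound 3 to compound 4 (0.14 log units; within the scatter) shows that the fluoro can be lost from this aromatic carbon with no change beyond the scatter, while a 2.4-fold lower number from compound 2 to compound 4 (0.38 log units; beyond the scatter) gives the first modest separation among the phenyl-bearing compounds, although compound 3 lies within the scatter of both. With an at least 16-fold lower number from compound 1 to compound 4 (1.21 log units; beyond the scatter), the unsubstituted phenyl alone accounts for a large step away from pyridin-4-yl, so neither the fluoro nor the methoxy is required for that step. The value of compound 1 is a limit: the limit of > 100000 nM in this assay, at which 1 of the 4 values shown sits.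

The compounds shown leave open how a chloro, a hydroxy or a dimethylamino group on this phenyl ring would read out. They also leave open whether a pyridin-3-yl would behave like pyridin-4-yl, and what a longer chain would do.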